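A few compounds are considered here, and "the series" means these few. Any claim that something is new, unique, unknown or untested is made for them only; others in the source may bear on it.

In an assay on COS-1 cells for displacement of a labelled ligand from sodium-dependent dopamine transporter (Homo sapiens) (on this read-out lower numbers stand for stronger inhibition and higher numbers for weaker inhibition), three compounds have so far been measured. Compound 1 `CCOC(=O)C1=C(c2ccc(Cl)c(Cl)c2)CCNC1` gives 922 nM, and compound 2 `COC(=O)C1=C(c2ccc(Cl)c(Cl)c2)CCC1` gives 1900 nM. Compound 3 `COC(=O)C1=C(c2ccc(C(C)(C)C)cc2)CCC1` gives 302000 nM. On these three numbers compound 3 stands highest: its value lies well beyond the scatter from that of compound 2, the nearest of the other two, and further still from that of compound 1, so among these three compound 3 is the weakest inhibitor. Going by the values given here, no two of the measured compounds differ in only one place, and so no single step between them can be isolated.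

Compound 4 `COC(=O)C1=C(c2ccc(C(C)=O)cc2)CCC1` has not yet been measured in this assay. It differs from compound 3 by acetyl in place of tert-butyl on an aromatic carbon. Among the compounds with values here, with no measured step of this kind to lean on, the expectation rests only on how far compound 3 sits from the other two. Since compound 3 gives 302000 nM, there is ample room for the number to fall, and a move toward stronger inhibition is expected, although a move beyond the scatter is uncertain. Compound 4 is therefore estimated to give 30000 nM, within a range from 5000 nM to 150000 nM. The expected step of a 10-fold lower number from compound 3 to compound 4 (1.00 log units; beyond the scatter) is thus toward a lower number.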

Compound 4, inhibition constant: 335000 nM
For compound 4 the middle estimate is 11-fold (1.05 log units) below the measured one; the measured number lies above the stated range.
By their numbers in this assay, from the lowest: compound 1; then compound 2; then compounds 3 and 4 (each within the scatter of the next).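

In this assay, going by these compounds alone, the change gives the first step in this set that can be read at a single place: acetyl in place of tert-butyl on an aromatic carbon, para to a group of 9 heavy atoms, amounts to a 1.1-fold higher number from compound 3 to compound 4 (0.05 log units; within the scatter) and so leaves the read-out unchanged in practical terms. At this position, then, the swap of four carbons for a group with one oxygen, one double bond outside the aromatic ring and one hydrogen-bond acceptor does not separate the two compounds, and compound 4 sits with compound 3 at the top of the numbers in this set. Nothing available here offers an explanation for this lack of separation.

The compounds shown leave open whether any group on this aromatic carbon would move the number beyond the scatter, for example an amine, a hydroxyl, a carboxylic acid or a longer chain such as n-butyl. They also leave open whether a plain hydrogen at this place would give a number apart from those of compound 3 and compound 4, since a single step between two groups cannot show how either compares with an unsubstituted ring.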